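Replacing 2-methylphenyl with 4-fluorophenyl in compound 3

This account rests on a few compounds, and the source may have more. Where it says the series, first, only, none or still open, it means among the compounds named here.

Measured in a functional assay on A549 cells (Homo sapiens) for cytotoxicity, read by MTT assay, with a stated time of 48 h; a higher number here means a weaker inhibitor, a lower number a stronger inhibitor:
- compound 1 `Cc1cccc(Cn2cc(COc3ccc4c(=O)ccoc4c3)nn2)c1` (20300 nM)
- compound 2 `Cc1ccccc1Cn1cc(COc2ccc3c(=O)ccoc3c2)nn1` (> 100000 nM)

Compound 2 has only a limit of the assay (> 100000 nM), not a number. Compound 3 `O=c1ccoc2cc(OCc3cn(Cc4ccc(F)cc4)nn3)ccc12` has 4-fluorophenyl in place of 2-methylphenyl on a saturated chain carbon bound to an aromatic nitrogen. Within the data shown here, one measured step bears on this place (an at least 4.9-fold higher number from compound 1 to compound 2 (0.69 log units; beyond the scatter)), and it lies beyond the scatter. Compound 3 lacks 2-methylphenyl, so a value nearer that of compound 1 (20300 nM) is expected. The expected step is toward a lower number (an at least 3.3-fold lower number from compound 2 to compound 3 (0.52 log units; beyond the scatter)). For compound 3 the estimated value is 30000 nM (expected range 10000 nM to 100000 nM).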

Compound 3, half-maximal inhibitory concentration: > 100000 nM
Compound 3: a limit, no number; the forecaster's own chance of this, stated with the estimate: 25%; middle value at least 3.3-fold (0.52 log units) away from the limit.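

In this assay, compound 3 gives only a limit of the assay, > 100000 nM. The 4-fluorophenyl group thus gives an at least 4.9-fold higher number from compound 1 to compound 3 (0.69 log units; beyond the scatter), so losing 2-methylphenyl does not by itself bring back a measurable value, and among these compounds only the 3-methylphenyl group of compound 1 gives a number. No step can be read between compound 2 and compound 3, as both values are limits: the limit of > 100000 nM in this assay, at which 2 of the 3 values shown sit.

The compounds shown leave open whether a number returns with 3-fluorophenyl, 4-methylphenyl or unsubstituted phenyl at this place. They also leave open what an amine or a carboxylic acid on this ring would give.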